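Thiomorpholine for morpholine on the thiocarbonyl carbon

A few compounds are considered here, and "the series" means these few. Any claim that something is new, unique, unknown or untested is made for them only; others in the source may bear on it.

Measured so far:
compound 1 `N/C(=N\NC(=S)N1CCOCC1)c1ccccn1` 87.2%
compound 2 `Cc1ccnc(/C(N)=N/NC(=S)N2CCOCC2)c1` 82.7%

In a functional assay on HeLa cells (Homo sapiens) for cytotoxicity, read by MTT assay, with a stated time of 72 h, tested at 100 uM (a higher number here means more inhibition of growth at the concentration tested, a lower number less inhibition of growth), compound 1 gives 87.2% and compound 2 gives 82.7%. Among the compounds with values here, the only step, a number 4.5 percentage points lower from compound 1 to compound 2 (within the scatter), lies within the scatter. Compound 2 thus sits at the lower of the two numbers shown, but within the scatter of compound 1.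

Compound 3 `Cc1ccnc(/C(N)=N/NC(=S)N2CCSCC2)c1` carries thiomorpholin-4-yl in place of morpholin-4-yl on a thiocarbonyl carbon. Within the data shown here, no measured step touches this position; the one step, a number 4.5 percentage points lower from compound 1 to compound 2 (within the scatter), concerns a different place and was within the scatter. No step beyond the scatter is therefore expected in this assay, so a number 0.7 percentage points lower from compound 2 to compound 3 (within the scatter) is the estimated change. For compound 3 the expected value is 82%, estimated between 70% and 92%.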

Compound 3, percent growth inhibition at one concentration: 91.6%
Beside the measured number, compound 3's estimate is 9.6 percentage points below it; the range from low to high includes it.
By their numbers in this assay, from the lowest: compounds 2, 1 and 3 (each within the scatter of the next).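

On a thiocarbonyl carbon, thiomorpholin-4-yl in place of morpholin-4-yl gives a number 8.9 percentage points higher from compound 2 to compound 3 (within the scatter) in this assay. Within the data shown here, this is the first reading at this position, and the change of ring hetero atom is tolerated without a step beyond the scatter. Nothing measured bears on a cause for this step.

On these data alone, whether piperidin-1-yl or an open-chain dimethylamino group on the same thiocarbonyl carbon would stay within the scatter remains open. So does whether thiomorpholin-4-yl behaves alike on the core of compound 1.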